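The source may hold more compounds than are shown below. What is called first, only, known or untested is meant among the compounds shown, and "the series" means these compounds.

Compound 1 `Cc1cnc(NC(=O)COc2ccc(/C=C3\SC(=O)NC3=O)cc2)s1` is one of a small set built around a shared core, and in a functional assay on HOP-62 cells (Homo sapiens) for cytotoxicity, read by sulforhodamine B assay, with a stated time of 48 h (a higher number here means a weaker inhibitor of growth, a lower number a stronger inhibitor of growth), compound 1 gives 30900 nM. Among the compounds with a single number, compound 1 has the highest value, and compound 2 `CCCCC1=NC2(CCCC2)C(=O)N1C(=O)COc1ccc(/C=C2/SC(=O)NC2=O)cc1` comes closest to it: in this assay compound 2 gives 29500 nM, a difference that sits within the usual scatter. Compound 3 `O=C(COc1ccc(/C=C2\SC(=O)NC2=O)cc1)Nc1nc2ccccc2s1` has been measured more than once, and in this assay compound 3 gives 28800 nM; 170 nM (2 entries); the spread between these entries the several entries of compound 3 in this assay, 28800 nM; 170 nM (2 entries) is far wider than the scatter, so no single number can be read from them.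

Compound 4 `O=C(COc1ccc(/C=C2\SC(=O)NC2=O)cc1)Nc1ncc([N+](=O)[O-])s1` is not yet measured. It differs from compound 1 in one place: nitro in place of methyl on an aromatic carbon. For the measured compounds named here, no measured pair in this set shows a change of this kind, so the direction of the step is open. The expectation is that the step from compound 1 to compound 4 a 1.5-fold lower number from compound 1 to compound 4 (0.19 log units; within the scatter) stays modest. Compound 4 is therefore estimated at 20000 nM, with a range from 3000 nM to 60000 nM.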

Compound 4, concentration for 50% growth inhibition: < 100000 nM
Compound 4 ended at the assay's limit; the forecaster's own chance of this, stated with the estimate: 10%; the middle value does not contradict the limit.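

In this assay compound 4 gives < 100000 nM, which is a limit of the assay and not a number. The step between compound 1 and compound 4 therefore cannot be read. The compounds shown leave open whether nitro in place of methyl changes growth inhibition at all.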